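This account rests on a few compounds, and the source may have more. Where it says the series, first, only, none or still open, it means among the compounds named here.

Compound 1 `O=C(O)c1ccccc1-c1ccc(CCc2ncc(Cc3cccc(Cl)c3)[nH]2)cc1` gives 31 nM. Compound 2 `O=C(O)c1ccccc1-c1ccc(CCc2ncc(CC3CCC3)[nH]2)cc1` gives 7.1 nM. Compound 3 `O=C(O)c1ccccc1-c1ccc(CCc2ncc(CC3CCCCCC3)[nH]2)cc1` gives 5.7 nM.

All three share one core and differ only in the group on a saturated chain carbon bound to an aromatic carbon. In an in vitro functional assay on cells for agonist activity at Bombesin receptor subtype-3 (Mus musculus), read by luminescence and calcium flux (a lower number here means that less compound is needed, a higher number that more compound is needed for the effect), compound 3 carries the lowest of the three numbers, although a 1.2-fold lower number from compound 2 to compound 3 (0.10 log units; within the scatter) lies within the scatter; the steps of a 5.4-fold lower number from compound 1 to compound 3 (0.74 log units; beyond the scatter) and a 4.4-fold lower number from compound 1 to compound 2 (0.64 log units; beyond the scatter) were modest and beyond it. Compound 4 `CC(C)(C)CCc1cnc(CCc2ccc(-c3ccccc3C(=O)O)cc2)[nH]1` differs from compound 3 as follows: neopentyl in place of cycloheptyl on a saturated chain carbon bound to an aromatic carbon. The step that bears most directly on this change is a 1.2-fold lower number from compound 2 to compound 3 (0.10 log units; within the scatter), an exchange of one ring-only group for another that moved nothing beyond the scatter. A further exchange of one non-aromatic group for another is therefore expected to give a 1.4-fold higher number from compound 3 to compound 4 (0.15 log units; within the scatter), nothing beyond the scatter. Compound 4 is estimated at 8 nM, with a range from 3 nM to 22 nM.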

Compound 4, half-maximal effective concentration: 6.2 nM
For compound 4 the middle estimate is 1.3-fold (0.11 log units) above the measured one, within the range that was stated.
By their numbers in this assay, from the lowest: compounds 3, 4 and 2 (each within the scatter of the next); then compound 1.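

In this assay the steps of a 1.1-fold higher number from compound 3 to compound 4 (0.04 log units; within the scatter) and a 1.1-fold lower number from compound 2 to compound 4 (0.06 log units; within the scatter) both lie within the scatter, so among these compounds a non-aromatic ring is not needed at this place and open-chain neopentyl serves as well. The step of a 5.0-fold lower number from compound 1 to compound 4 (0.70 log units; beyond the scatter) shows that neopentyl, like cyclobutyl and cycloheptyl, stands clear of 3-chlorophenyl. Nothing available explains why these groups read alike. Open, on these data alone, is whether a group bearing an amine, a hydroxyl or a carboxylic acid would be tolerated here. A longer chain, such as n-octyl, also remains untested among the compounds shown.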